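Benzyl substituent changes on the shared core

The source may hold more compounds than are shown below. What is called first, only, known or untested is meant among the compounds shown, and "the series" means these compounds.

Measured so far in a functional assay on FM3A cells (Mus musculus) for cytotoxicity, read by cell counting, with a stated time of 2 days; a lower number here means a stronger inhibitor, a higher number a weaker inhibitor: compound 1 `Nc1cccc(/C=C2\SC(=O)N(Cc3ccc(F)cc3)C2=O)c1` gives 140000 nM. Compound 2 `Nc1cccc(/C=C2\SC(=O)N(Cc3ccc(C(F)(F)F)cc3)C2=O)c1` gives only a limit, > 250000 nM.

Compound 2 therefore stands at the limit of this assay, (the limit of > 250000 nM in this assay, at which 1 of the 2 values shown sits), and no number is known for it. Compound 3 `Nc1cccc(/C=C2\SC(=O)N(Cc3ccc(Cl)cc3)C2=O)c1` differs from compound 2 by chloro in place of trifluoromethyl on an aromatic carbon. Within the data shown here, the only measured step that bears on this position is an at least 1.7-fold higher number from compound 1 to compound 2 (0.25 log units; that floor lies within the scatter), and its floor lies within the scatter, so the direction of that step is not secured. Chloro is neither fluoro nor trifluoromethyl, and the two measured compounds give no further guidance. Compound 1 is the nearest anchor with a number, 140000 nM. For compound 3 the expected value in this assay is 180000 nM, with a range of 70000 nM to 400000 nM. The estimated step of an at least 1.3-fold lower number from compound 2 to compound 3 (0.14 log units; that floor lies within the scatter) can only be read against a limit and may itself end in a limit.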

Compound 3, half-maximal inhibitory concentration: 246000 nM
For compound 3 the middle estimate is 1.4-fold (0.14 log units) below the measured one; the measured number falls inside the stated range.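

Chloro in place of fluoro gives a 1.8-fold higher number from compound 1 to compound 3 (0.24 log units; within the scatter) in this assay and so this pair, the first at this position with two actual numbers, shows no secured difference between the two substituents. Chloro in place of trifluoromethyl gives an at least 1.0-fold lower number from compound 2 to compound 3 (0.00 log units; that floor lies within the scatter) in this assay but this step starts from a limit, and trifluoromethyl therefore cannot be ranked against either chloro or fluoro. Compound 2 remains at a limit and has no number: the limit of > 250000 nM in this assay, at which 1 of the 3 values shown sits.

On these data alone, whether an amine, a carboxylic acid or a methoxy group at this place would move the number beyond the scatter remains open. So does the outcome of leaving plain hydrogen at this place on the shared core.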